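This account rests on a few compounds, and the source may have more. Where it says the series, first, only, none or still open, it means among the compounds named here.

Measured in a functional assay on HEK293 cells for agonist activity at probable G-protein coupled receptor 27 (Homo sapiens), read by a luciferase reporter and beta-arrestin recruitment, with a stated time of 10 min; a higher number here means that more compound is needed for the effect, a lower number that less compound is needed:
compound 1 `O=C(Nc1ccc(S(=O)(=O)NCc2ccccc2)cc1)c1ccc(Cl)cc1Cl`: > 100000 nM, a limit of the assay
compound 2 `O=C(Nc1ccc(S(=O)(=O)Nc2ccccc2)cc1)c1ccc(Cl)cc1F`: 3980 nM
compound 3 `O=S(=O)(Nc1ccccc1)c1ccc(NS(=O)(=O)c2ccc(Cl)cc2Cl)cc1`: > 100000 nM, a limit of the assay

Compound 1 stands only at the limit, with no number. Compound 3 likewise gives only a limit. Hence the limit of > 100000 nM in this assay, at which 2 of the 3 values shown sit, covers two of the three values shown. For the measured compounds named here, compound 2, which carries phenyl on the sulfonamide nitrogen, is the one compound with a number, and in this assay compound 2 gives 3980 nM. Compound 4 `O=C(Nc1ccc(S(=O)(=O)Nc2ccccc2Cl)cc1)c1ccc(Cl)cc1Cl` differs from compound 1 by 2-chlorophenyl in place of benzyl on a sulfonamide nitrogen, again an aryl group on that nitrogen as in compound 2. Going by the values given here, no measured step sets the size. The step expected here is an at least 16-fold lower number from compound 1 to compound 4 (1.22 log units; beyond the scatter), downward and beyond the scatter. Compound 4 is estimated at 6000 nM, range 1000 nM to 60000 nM, with a real chance of another limit.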

Compound 4, half-maximal effective concentration: 1260 nM
The estimate for compound 4 lay 4.8-fold (0.68 log units) above the measured number; low and high end bracket the measured number.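

In this assay, for the compounds shown here, 2-chlorophenyl in place of benzyl on a sulfonamide nitrogen gives an at least 79-fold lower number from compound 1 to compound 4 (1.89 log units; beyond the scatter), the first step that can be read at this position. The step has only a bound, compound 1 being a limit of the assay: the limit of > 100000 nM in this assay, at which 2 of the 4 values shown sit.

An aryl group on that nitrogen goes with a number in compound 2 and compound 4, but compound 3, with phenyl there, goes against this and stands at a limit.

Open, on these data alone, is how much of the step belongs to the chlorine itself. Also open, as far as these compounds go, is how a longer chain or a carboxylic acid on that nitrogen would read.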